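The source may report more compounds than this note shows. Statements on the series, on what has been measured and on what is new or still open speak of the compounds shown alone.

Measured compounds in this series:
- compound 1, `CCOC(=O)c1ccc(/N=N/N(C)C(=O)OCOC(=O)c2ccccc2O)cc1`: 0.567 h
- compound 2, `Nc1ccc(S(=O)(=O)N(COC(=O)c2ccccc2)c2cncs2)cc1`: 0.002 h
- compound 3, `CCOC(=O)CNC(=O)OCOC(=O)c1cccnc1`: 0.00717 h

In an ADME assay on a cell-free system (plasma, Homo sapiens) for metabolic stability (a higher number here means that the compound lasts longer, a lower number that the compound disappears faster), compound 1 gives the highest of the three numbers; the nearest is compound 3, whose value sits well beyond the scatter below it, and compound 2 lies further below still. Among the measured compounds shown here, no two of the measured compounds differ in only one place, so no single step between them can be read from these numbers.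

Compound 4, `CCOC(=O)c1ccc(/N=N/N(C)C(=O)OCOC(C)=O)cc1`, has not yet been measured in this assay. It differs from compound 1 by methyl in place of 2-hydroxyphenyl on a carbonyl carbon, the carbonyl carbon bearing an oxygen next to a carbonyl group. The measured compounds give no guide to the size of such a change, and the expectation rests on compound 1 alone, which gives 0.567 h as the only direct anchor. A moderate downward step is expected, a 3.8-fold lower number from compound 1 to compound 4 (0.58 log units; beyond the scatter), beyond the usual scatter but well short of the gap to compound 2. Compound 4 is therefore estimated at 0.15 h in this assay, within a range of 0.03 h to 0.6 h.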

Compound 4, half-life: 0.2 h
Beside the measured number, compound 4's estimate is 1.3-fold (0.12 log units) below it; the measured number falls inside the stated range.
By their numbers in this assay, from the lowest: compound 2; then compound 3; then compound 4; then compound 1.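

Methyl in place of 2-hydroxyphenyl on a carbonyl carbon gives, in this assay, a 2.8-fold lower number from compound 1 to compound 4 (0.45 log units; beyond the scatter), the first step in the series that can be read at a single place. It shows that the group on this carbonyl carbon affects the half-life, and that the change, though beyond the scatter, is modest even with the six-membered aromatic ring and its hydrogen-bond donor gone. Nothing in hand accounts for the size or direction of this step.

Open, as far as these compounds go, is whether the step follows the ring or its hydroxyl, and how a tert-butyl group or a longer chain such as butyl would read on the same carbonyl carbon. From the compounds shown here alone, the step also rests on one pair, so whether it carries over to another core remains unknown.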